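Fluorine Added to the Anilide Ring of Compound 3

The source may report more compounds than this note shows. Statements on the series, on what has been measured and on what is new or still open speak of the compounds shown alone.

Of the compounds shown here, three have so far been measured in a physicochemical assay for solubility, in phosphate buffer, measured as kinetic solubility, with a stated time of 1 h, at pH 7.4; on this read-out higher numbers stand for higher solubility and lower numbers for lower solubility. Compound 1 `Cc1cc(C)cc(NC(=O)COc2cc(C)nc3ccc(C(F)(F)F)cc23)c1` gives 10000 nM, and compound 2 `COc1ccc2nc(C)cc(NC(=O)C(=O)Nc3cc(C)cc(C)c3)c2c1` gives 10000 nM. Compound 3 `COc1ccc2nc(C)cc(OCC(=O)Nc3ccccc3)c2c1` gives 63000 nM, the highest of the three numbers; its gaps to compound 1 and to compound 2 both lie beyond the usual scatter, so compound 3 dissolves clearly better than either.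

The next compound, compound 4 `COc1ccc2nc(C)cc(OCC(=O)Nc3ccc(F)cc3)c2c1`, differs from compound 3 in a single place: fluoro in place of hydrogen on an aromatic carbon. Among the compounds with values here, no pair of measured compounds shows this exact change, so the expectation rests on compound 3 alone. One added fluorine is a small change to a molecule of this size, and the step from compound 3 to compound 4 is expected to be small, most likely a slight drop that stays within the scatter of repeated measurements, namely a 1.6-fold lower number from compound 3 to compound 4 (0.20 log units; within the scatter). Compound 4 is therefore estimated to give 40000 nM in this assay, with a plausible range from 15000 nM to 100000 nM.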

Compound 4, solubility: 104000 nM
Beside the measured number, compound 4's estimate is 2.6-fold (0.41 log units) below it, and the stated range ends below it.
By their numbers in this assay, from the lowest: compounds 1 and 2 (each within the scatter of the next); then compounds 3 and 4 (each within the scatter of the next).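

Within the data shown here, this is the first step that changes only one place, and it gives a direct reading of the six-membered aromatic ring of carbon only that carries the anilide nitrogen. In this assay, fluoro in place of hydrogen on an aromatic carbon, para to a large group, gives a 1.7-fold higher number from compound 3 to compound 4 (0.22 log units; within the scatter), so at this position this single swap cannot be told apart from the ordinary variation between repeated measurements. No measurement is available that would explain why the two numbers lie so close.

This one swap does not show whether a different group at the same carbon, such as an amine or a carboxylic acid, would give a step beyond the scatter. It also leaves open whether fluoro on another carbon of this ring would give a similarly small step.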